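Cyano in Place of Mesylate on a Pyridyl Benzamide

This account rests on a few compounds, and the source may have more. Where it says the series, first, only, none or still open, it means among the compounds named here.

Measured compounds:
compound 1, `Cc1cccc(C(=O)Nc2cccc(C)n2)c1`, compound 1 in a functional assay on CHO cells for antagonist activity at metabotropic glutamate receptor 5 (Homo sapiens), read by inositol phosphate accumulation (on this read-out lower numbers stand for stronger inhibition and higher numbers for weaker inhibition), gives 5900 nM
compound 2, `Cc1cccc(NC(=O)c2cccc(C(F)(F)F)c2)n1`, compound 2 gives "not determined" (no result reported)
compound 3, `Cc1cccc(NC(=O)c2cccc(OS(C)(=O)=O)c2)n1`, compound 3 gives "not determined" (no result reported)

Three compounds share the core of compound 1, and they differ only in the group carried on the benzamide ring. Of the three, only compound 1, bearing a methyl, has a number in this assay. Compound 3, with a (methylsulfonyl)oxy group, has no single number, and it is one of two entries without one, the other being compound 2 with its trifluoromethyl. Compound 3 therefore stands nowhere on the scale; it offers no anchor of its own, and the only measured point in the set is compound 1.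

The next compound, compound 4, `Cc1cccc(NC(=O)c2cccc(C#N)c2)n1`, is obtained from compound 3 by the change (cyano in place of (methylsulfonyl)oxy on an aromatic carbon). The group that leaves is the larger of the two; what enters is a nitrile of two heavy atoms, placed on the same aromatic carbon, meta to the large group.

For the measured compounds named here, no step between measured compounds is available for this assay, so nothing measured tells how a (methylsulfonyl)oxy group compares with a cyano at this position. Judged only against compound 1, the sole number in the set, compound 4 is expected to land in a comparable or somewhat stronger region in this assay, with wide uncertainty. The estimate for compound 4 is 800 nM, within a range from 150 nM to 4000 nM.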

Compound 4, half-maximal inhibitory concentration: 5330 nM
Compound 4: the middle estimate sits 6.7-fold (0.82 log units) below what was measured; measured number outside the range, above it.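

In this assay, for the compounds shown here, putting cyano in place of methyl on the aromatic carbon gives a 1.1-fold lower number from compound 1 to compound 4 (0.04 log units; within the scatter), which is the first readable step in the set and shows that these two groups cannot be told apart at this position. The change from (methylsulfonyl)oxy to cyano itself cannot be read, as compound 3 has no single number, so the new result speaks only to methyl and cyano and says nothing about how the larger group behaves here. No measured evidence bears on why methyl and cyano give values so close together.

Going by these compounds alone, with only two groups on the scale at this position, it remains open whether any other group on the same aromatic carbon, such as an amine, a carboxylic acid or a chlorine atom, would give a number beyond the scatter of these two. As far as these compounds go, it is also open whether the same closeness of methyl and cyano would hold if the shared core carried a further group elsewhere, such as a longer chain.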